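A few compounds are considered here, and "the series" means these few. Any claim that something is new, unique, unknown or untested is made for them only; others in the source may bear on it.

In a functional assay on HEK293 cells for activation of melanin-concentrating hormone receptor 1 (Rattus norvegicus), read by inositol phosphate accumulation (on this read-out higher numbers stand for an effect only at larger amounts of compound and lower numbers for an effect already at smaller amounts), two compounds have been measured so far. Compound 1 `CC(=O)NC1CCN(c2ccc3cc(NC(=O)CCc4ccc(C(F)(F)F)cc4)ccc3n2)C1` gives 440 nM, while compound 2 `CNC(=O)NC1CCN(c2ccc3cc(NC(=O)CCc4ccc(C(F)(F)F)cc4)ccc3n2)C1` gives 30 nM, the lowest of the two numbers. Among the compounds with values here, the one step known, a 15-fold lower number from compound 1 to compound 2 (1.17 log units; beyond the scatter), shows that a small change at the carbonyl of the side chain can move the read-out a great deal. Compound 3 `CCN(CC)c1ccc2cc(NC(=O)CCc3ccc(C(F)(F)F)cc3)ccc2n1` has not been measured. It differs from compound 2 by diethylamino in place of 3-((methylcarbamoyl)amino)pyrrolidin-1-yl on an aromatic carbon. Within the data shown here, no measured pair covers this change directly: the step from compound 1 to compound 2 touches only part of the group that leaves and says nothing about taking away the whole group. Still, a change at this part of the molecule produced a large step once, so a large step is expected here as well, most likely toward a higher number. Compound 3 is therefore expected to give about 1200 nM, within a range from 120 nM to 12000 nM, which means an estimated step of a 40-fold higher number from compound 2 to compound 3 (1.60 log units; beyond the scatter).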

Compound 3, half-maximal effective concentration: 830 nM
Compound 3: middle estimate off by 1.4-fold (0.16 log units), on the high side; the range from low to high includes it.
By their numbers in this assay, from the lowest: compound 2; then compounds 1 and 3 (each within the scatter of the next).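

In this assay the aromatic carbon next to the ring nitrogen proves sensitive to the whole group, not only to the end of its side chain: diethylamino in place of 3-((methylcarbamoyl)amino)pyrrolidin-1-yl gives a large step (a 28-fold higher number from compound 2 to compound 3 (1.44 log units; beyond the scatter)). Against the acetamido version the same swap stays small (a 1.9-fold higher number from compound 1 to compound 3 (0.28 log units; within the scatter)), so among these three compounds only the methylamino carbonyl version stands apart, while the acetyl-bearing ring and the ring-free diethylamino cannot be told apart. No measurement here explains why the read-out behaves this way.

Open, as far as these compounds go, is how a plain pyrrolidin-1-yl or a 3-aminopyrrolidin-1-yl group would read at this position. Also open, from the compounds shown here alone, is whether the methylurea on an open ethylamino chain, without the ring, would keep the low number of compound 2.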